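The compounds below may be only part of what the source reports. "The series", "measured", "known", "first", "only" and "open" are said of these compounds alone.

Working notes on the series in a functional assay on HT-29 cells (Homo sapiens) for cytotoxicity, read by MTT assay, with a stated time of 72 h; on this read-out lower numbers stand for stronger inhibition and higher numbers for weaker inhibition. Compound 2 `Fc1ccc(Nc2cc(Nc3ccc(Oc4ccncc4-c4cccnc4)c(F)c3)ncn2)cc1` gives 330 nM. Compound 1 `Fc1ccc(Nc2cc(Nc3ccc(Oc4ccncc4-c4cccnc4)c(F)c3)ncn2)cc1F` gives 2320 nM; the step of a 7.0-fold higher number from compound 2 to compound 1 (0.85 log units; beyond the scatter) corresponds to fluoro in place of hydrogen on an aromatic carbon. Compound 3 `Cn1cc(-c2ccccc2)cc(C(=O)Nc2ccc(Oc3ccncc3-c3cccnc3)c(F)c2)c1=O` gives 7420 nM, the highest of the three numbers; how its core differs from that of compound 2 is not broken down here. Compound 4 `Cn1cc(-c2ccc(F)cc2)cc(C(=O)Nc2ccc(Oc3ccncc3-c3cccnc3)c(F)c2)c1=O` is not yet measured and differs from compound 3 by fluoro in place of hydrogen on an aromatic carbon. This is the same kind of change as from compound 2 to compound 1, not the same: there the entering fluoro sat ortho to a fluoro group and meta to a large group, here it sits para to a large group, on a different core. For compound 4 the expected step is a 1.5-fold higher number from compound 3 to compound 4 (0.17 log units; within the scatter), a smaller weakening than seen in a 7.0-fold higher number from compound 2 to compound 1 (0.85 log units; beyond the scatter) given the changed surroundings. Compound 4 is estimated at 11000 nM, with a range from 3500 nM to 35000 nM.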

Compound 4, half-maximal inhibitory concentration: 11200 nM
Beside the measured number, compound 4's estimate is 1.0-fold (0.01 log units) below it; measured number inside the range.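

In this assay fluoro in place of hydrogen on the phenyl reads a 1.5-fold higher number from compound 3 to compound 4 (0.18 log units; within the scatter), so on this core the change has no effect that can be told from the scatter. The size of the step does not carry from one core to the other: the same change on two cores in this assay, a 7.0-fold higher number (0.85 log units; beyond the scatter) from compound 2 to compound 1 and a 1.5-fold higher number (0.18 log units; within the scatter) from compound 3 to compound 4, 4.7-fold (0.67 log units) apart, beyond the scatter of two such steps

This rests on a single pair per core, and the two pairs differ in the surroundings of the entering fluoro as well as in the core, so it does not show which of these accounts for the gap, nor does it give a rule for other cores.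

Open, going by these compounds, is whether a chloro or a methoxy in place of that hydrogen on compound 3 would stay equally close to its number. Also open, on these data alone, is how the fluoro step reads on any further core.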